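The compounds below may be only part of what the source reports. "The series", "measured", "known", "first", "only" and "open" are said of these compounds alone.

Measured compounds:
compound 1, `COc1cc(-c2cc(-c3ccc(Br)cc3)nc(N)n2)cc(OC)c1OC`, giving 100000 nM in an ADME assay on THP-1 cells (Homo sapiens) for cytotoxicity, read by MTT assay; a higher number here means that more compound is tolerated, a lower number that less compound is tolerated
compound 2, `COc1cc(C2CC(c3ccc(Cl)cc3)=NN2C(C)=O)cc(OC)c1OC`, giving 100000 nM in this assay

Compound 2 stands level with compound 1 in this assay at the digits given; the two readings lie within the scatter of each other, so nothing separates them. Within the data shown here, compound 1 has a different core, and no step between the two is drawn, so only the shared reading is taken from this pair.

Compound 3, `COc1cc(C2CC(c3ccc(Br)cc3)=NN2C(C)=O)cc(OC)c1OC`, keeps the core of compound 2 and differs in one place: bromo in place of chloro on an aromatic carbon. Compound 1 already carries a bromo on an aromatic carbon and returns the same reading in this assay as the chloro-bearing compound 2, though on another core. Among the measured compounds shown here, no step between measured compounds covers this change directly. A step from compound 2 to compound 3 in this assay of no size beyond the scatter is expected, in neither direction. For compound 3 the expected value in this assay is 100000 nM, with a range from 50000 nM to 100000 nM. That amounts to an expected step of no change at the digits printed from compound 2 to compound 3 (within the scatter).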

Compound 3, half-maximal cytotoxic concentration: 100000 nM
For compound 3 middle estimate and measured number coincide at the digits printed; the measured number falls inside the stated range.
By their numbers in this assay, from the lowest: compounds 1, 2 and 3 (each within the scatter of the next).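

In this assay, the 4-chlorophenyl to 4-bromophenyl change, a bromo in place of chloro on an aromatic carbon para to a large group, reads as no change at the digits printed from compound 2 to compound 3 (within the scatter). Among these compounds, this is the first comparison that differs in one place on a single core, so the halogen exchange can now be read directly rather than inferred from compound 1, whose core is different and which shares only its reading with compound 2. At this position, the two halogens are therefore not separated in this assay, although the pair says nothing about any other position or core, and no measurement is at hand that could account for the result.

With only chloro and bromo shown at this place, it remains open whether a group of another kind, such as an amine, a carboxylic acid or a longer chain, would depart from the reading of compound 3, 100000 nM. Also open, as far as these compounds go, is whether the same exchange would read alike on the core of compound 1, where only the bromo form, compound 1, stands at 100000 nM.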